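A few compounds are considered here, and "the series" means these few. Any claim that something is new, unique, unknown or untested is made for them only; others in the source may bear on it.

Compound 1 `CSc1cccc(N2CCN(Cc3nc[nH]c3C)C2=O)c1` gives 120 nM in a functional assay (Cavia porcellus) for antagonist activity at Serotonin 3 (5-HT3) receptor (Homo sapiens); a higher number here means a weaker inhibitor, a lower number a stronger inhibitor. Compound 2 `Cc1[nH]cnc1CN1CCN(c2cccc(C(F)(F)F)c2)C1=O` gives 68.5 nM in this assay.

Among the measured compounds shown here, compound 2 sits at one end of these two numbers, but the single measured step, a 1.8-fold lower number from compound 1 to compound 2 (0.24 log units; within the scatter), is within the scatter. Compound 3 `Cc1[nH]cnc1CN1CCN(c2cccc(F)c2)C1=O` differs from compound 2 by fluoro in place of trifluoromethyl on an aromatic carbon. For the measured compounds named here, no measured step exchanges trifluoromethyl for fluoro; the exchange of methylsulfanyl for trifluoromethyl on that aromatic carbon moved the number little, and that is all there is to go on. The expected step is therefore a 1.5-fold higher number from compound 2 to compound 3 (0.16 log units; within the scatter), not clearly beyond the scatter. Compound 3 is thus estimated at 100 nM, within a range from 35 nM to 300 nM.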

Compound 3, antagonist equilibrium constant: 88.3 nM
Estimate against measurement, compound 3: 1.1-fold (0.05 log units) above; the range from low to high includes it.
By their numbers in this assay, from the lowest: compounds 2, 3 and 1 (each within the scatter of the next).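

Swapping trifluoromethyl, with its four heavy atoms, for fluoro, with one, hardly registers at this place on the aromatic ring in this assay: the result is a 1.3-fold higher number from compound 2 to compound 3 (0.11 log units; within the scatter). The exchange of methylsulfanyl for fluoro reads the same, a 1.4-fold lower number from compound 1 to compound 3 (0.13 log units; within the scatter), so all three groups now give numbers within the scatter of one another. No evidence is available to explain this result. The compounds shown leave open whether an amine, a carboxylic acid or a longer chain at this place would stay within that scatter.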